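The source may hold more compounds than are shown below. What is called first, only, known or untested is meant among the compounds shown, and "the series" means these compounds.

Compound 1 `CC(=O)N1CCc2nc(C#Cc3ccccc3)sc2C1` in an assay on HEK293 cells for negative allosteric modulation of metabotropic glutamate receptor 5 (Homo sapiens), read by FLIPR, with a stated time of 1 h (on this read-out higher numbers stand for weaker inhibition and lower numbers for stronger inhibition), gives 90 nM.
Compound 2 `O=C(C1CC(F)C1)N1CCc2nc(C#Cc3ccccc3)sc2C1` gives only a limit of this assay, > 10000 nM.

Compound 2 therefore sits at the limit of > 10000 nM in this assay, at which 1 of the 2 values shown sits, so its true potency is known only as weaker than a number, not as a number. For the measured compounds named here, the single measured step that reaches it, an at least 110-fold higher number from compound 1 to compound 2 (2.04 log units; beyond the scatter), shows that exchanging the methyl on the carbonyl carbon for a fluorinated four-membered ring removed inhibition past what this assay can report.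

Compound 3 `O=C(C1CCC(F)(F)CC1)N1CCc2nc(C#Cc3ccccc3)sc2C1` takes the next step: 4,4-difluorocyclohexyl in place of 3-fluorocyclobutyl on a carbonyl carbon. Going by the values given here, no measured step shows a ring of this size on the carbonyl carbon, so only the step from compound 1 to compound 2 bears on it. Given that a smaller fluorinated ring already reached the limit, compound 3 is expected to stay there, with no step beyond the scatter, a step that the limit leaves unreadable from compound 2 to compound 3. The estimate for compound 3 is 15000 nM, within 3000 nM to 100000 nM.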

Compound 3, half-maximal inhibitory concentration: > 10000 nM
Compound 3 gave a limit, no number; the forecaster's own chance of this, stated with the estimate: 75%; the middle value does not contradict the limit.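

In this assay, putting 4,4-difluorocyclohexyl in place of the methyl on the carbonyl carbon gives an at least 110-fold higher number from compound 1 to compound 3 (2.04 log units; beyond the scatter), so the loss seen with 3-fluorocyclobutyl is not confined to that one four-membered ring. The two fluorinated rings cannot be ranked against each other, since the step that separates them cannot be read. Compound 3, like compound 2, gives a limit of the assay and not a number: the limit of > 10000 nM in this assay, at which 2 of the 3 values shown sit.

The compounds shown leave open how much can be added to the methyl of compound 1 before inhibition is lost. An ethyl or a cyclopropyl on the carbonyl carbon, or a plain cyclobutyl or cyclohexyl without fluorine, would show whether the loss follows the size of the group or the fluorine atoms.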